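From a Hydroxy to a 4-Bromobutoxy Group

This account rests on a few compounds, and the source may have more. Where it says the series, first, only, none or still open, it means among the compounds named here.

- compound 1 `COc1ccc(N(C)c2ccnc(Cl)n2)cc1F` gives 844 nM
- compound 2 `COc1ccc(N(C)c2ccnc(Cl)n2)cc1[N+](=O)[O-]` gives 6120 nM
- compound 3 `COc1ccc(N(C)c2ccnc(Cl)n2)cc1O` gives 464 nM

These numbers come from a functional assay on HepG2 cells (Homo sapiens) for antiproliferative activity, read by MTT assay, with a stated time of 48 h; on this read-out lower numbers stand for stronger inhibition and higher numbers for weaker inhibition. Compound 3, at 464 nM, cannot be told apart from one neighbour, since a 1.8-fold lower number from compound 1 to compound 3 (0.26 log units; within the scatter) is a small step. It stands clearly apart from the other, with a 13-fold lower number from compound 2 to compound 3 (1.12 log units; beyond the scatter).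

Compound 4 `COc1ccc(N(C)c2ccnc(Cl)n2)cc1OCCCCBr` keeps the core of compound 3 and changes one place: 4-bromobutyl in place of hydrogen on an oxygen on an aromatic ring. Hydroxy thus becomes 4-bromobutoxy. Among the measured compounds shown here, no measured compound carries a chain on this oxygen, so the only guides are swaps of the group on that aromatic carbon. There, a 7.3-fold higher number from compound 1 to compound 2 (0.86 log units; beyond the scatter) shows that the number can respond strongly to the group, though not every swap does so. The data do not fix a direction, but a modest rise in this assay seems the likelier outcome, and the uncertainty is wide. The expected step is a 3.2-fold higher number from compound 3 to compound 4 (0.51 log units; beyond the scatter). For compound 4 the estimated value is 1500 nM, with an expected range from 250 nM to 9000 nM.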

Compound 4, half-maximal inhibitory concentration: 168 nM
Beside the measured number, compound 4's estimate is 8.9-fold (0.95 log units) above it; measured number below the stated range.
By their numbers in this assay, from the lowest: compound 4; then compounds 3 and 1 (each within the scatter of the next); then compound 2.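

The oxygen of compound 3 accepts a 4-bromobutyl chain without any loss in this assay and shows a 2.8-fold lower number from compound 3 to compound 4 (0.44 log units; beyond the scatter) instead, something the swaps among fluoro, nitro and hydroxy could not reveal. The chain also stands clear of the other two groups, with a 5.0-fold lower number from compound 1 to compound 4 (0.70 log units; beyond the scatter) and with a 36-fold lower number from compound 2 to compound 4 (1.56 log units; beyond the scatter) as well, so compound 4 gives the lowest number of the four. No measurement at hand offers a reason for this drop.

The compounds shown leave open whether the bromine or the carbon chain accounts for the step, and a plain butoxy group or the same chain ending in an amine would separate the two. As far as these compounds go, how a shorter or a longer chain on this oxygen would behave also remains unknown.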